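The source may hold more compounds than are shown below. What is called first, only, known or untested is meant among the compounds shown, and "the series" means these compounds.

Measured in an ADME assay on MDBK cells (Bos taurus) for cytotoxicity; a higher number here means that more compound is tolerated, a lower number that less compound is tolerated:
- Compound 1 `COc1ccccc1Cn1ccc2nc(-c3ccccc3)nc-2c1`: > 100000 nM (a limit)
- Compound 2 `Clc1ccc(Cn2ccc3nc(-c4ccccc4)nc-3c2)cc1Cl`: 71000 nM
- Compound 3 `c1ccc(-c2nc3cc[nH]cc-3n2)cc1`: > 100000 nM (a limit)

Compound 3 gives only a limit in this assay, > 100000 nM. Compound 4 `CCC(CC)Cn1ccc2nc(-c3ccccc3)nc-2c1` carries 2-ethylbutyl in place of hydrogen on an aromatic nitrogen. Among the compounds with values here, no measured step makes this replacement directly. The nearest is a change of aryl group on the saturated chain carbon bound to an aromatic nitrogen, an at least 1.4-fold lower number from compound 1 to compound 2 (0.14 log units; that floor lies within the scatter). The values also gather at one point, (the limit of > 100000 nM in this assay, at which 2 of the 3 values shown sit). A small fall or nothing beyond the scatter is therefore expected, and the estimated step is an at least 1.2-fold lower number from compound 3 to compound 4 (0.09 log units; that floor lies within the scatter). For compound 4 the expected value is 80000 nM, with an estimated range of 30000 nM to 130000 nM.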

Compound 4, half-maximal cytotoxic concentration: > 100000 nM
Compound 4: only a limit was reported (the forecaster's own chance of this, stated with the estimate: 45%); middle value at least 1.2-fold (0.09 log units) away from the limit.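

With 2-ethylbutyl on the aromatic nitrogen, compound 4 shows that a chain without a ring can stand at this position in this assay, where the earlier substituted compounds carried an aryl group on the saturated chain carbon. Pentan-3-yl in place of 3,4-dichlorophenyl gives an at least 1.4-fold higher number from compound 2 to compound 4 (0.14 log units; that floor lies within the scatter), while the steps to compound 4 from compound 1 and compound 3 cannot be read. The series therefore gives little resolution at this position: the limit of > 100000 nM in this assay, at which 3 of the 4 values shown sit.

Going by these compounds, how far the number would move with an amine or a carboxylic acid on this chain remains open. So does the effect of a longer chain.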